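Acetyl for methyl: compound 3 to compound 4

The source may hold more compounds than are shown below. What is called first, only, known or untested is meant among the compounds shown, and "the series" means these compounds.

Three measured compounds share one core and differ only on one aromatic carbon of the six-membered aromatic ring of carbon only that hangs from the imine. Compound 1 `Cc1ccc(S(=O)(=O)n2cc(COC3=C/C(=N\c4ccc(F)cc4)c4ccccc4C3=O)nn2)cc1` carries fluoro there and gives 7520 nM in a functional assay on HL-60 cells (Homo sapiens) for cytotoxicity, read by MTT assay, with a stated time of 72 h; a higher number here means a weaker inhibitor, a lower number a stronger inhibitor. Compound 2 `Cc1ccc(S(=O)(=O)n2cc(COC3=C/C(=N\c4ccccc4)c4ccccc4C3=O)nn2)cc1` carries hydrogen and gives 6710 nM in this assay. Compound 3 `Cc1ccc(/N=C2\C=C(OCc3cn(S(=O)(=O)c4ccc(C)cc4)nn3)C(=O)c3ccccc32)cc1` carries methyl and gives 5420 nM in this assay. The three numbers sit close together: a 1.1-fold lower number from compound 1 to compound 2 (0.05 log units; within the scatter), a 1.4-fold lower number from compound 1 to compound 3 (0.14 log units; within the scatter) and a 1.2-fold lower number from compound 2 to compound 3 (0.09 log units; within the scatter). Compound 3 returns the lowest of the three numbers, its nearest neighbour being compound 2 and its furthest compound 1, but both gaps lie within the scatter, so no ranking among them is claimed.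

Compound 4 `CC(=O)c1ccc(/N=C2\C=C(OCc3cn(S(=O)(=O)c4ccc(C)cc4)nn3)C(=O)c3ccccc32)cc1` is the next member. acetyl in place of methyl on an aromatic carbon The measured steps that bear on this change are the two that vary the same aromatic carbon, a 1.4-fold lower number from compound 1 to compound 3 (0.14 log units; within the scatter) and a 1.2-fold lower number from compound 2 to compound 3 (0.09 log units; within the scatter), and neither leaves the scatter. Going by the values given here, the entering acetyl is larger than any group tried so far, and no measured step tests a group of that kind, so the working expectation is a step of a 1.0-fold higher number from compound 3 to compound 4 (0.01 log units; within the scatter), that is, nothing beyond the scatter. Compound 4 is therefore estimated at 5500 nM in this assay, with an expected range from 2500 nM to 12000 nM.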

Compound 4, half-maximal inhibitory concentration: 5300 nM
Compound 4: middle estimate off by 1.0-fold (0.02 log units), on the high side, within the range that was stated.
By their numbers in this assay, from the lowest: compounds 4, 3, 2 and 1 (each within the scatter of the next).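

Going by these compounds alone, at this aromatic carbon, para to a large group, acetyl is the only group of the four with a double bond outside aromatic rings and a hydrogen-bond acceptor, yet in this assay its steps from the other three compounds all stay within the scatter (a 1.0-fold lower number from compound 3 to compound 4 (0.01 log units; within the scatter); a 1.3-fold lower number from compound 2 to compound 4 (0.10 log units; within the scatter); a 1.4-fold lower number from compound 1 to compound 4 (0.15 log units; within the scatter)). The flat picture left by fluoro, hydrogen and methyl therefore now extends to a group of 3 heavy atoms containing oxygen, and these four groups cannot be ranked from these numbers. No supporting measurement is available to explain why the four numbers stay so close.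

From the compounds shown here alone, it remains open whether a group of another kind on this carbon, such as an amine, a carboxylic acid or a longer alkyl chain, would produce a step beyond the scatter. Also open, going by these compounds, is whether replacing the 4-methylphenyl on the sulfonyl group, rather than changing the ring on the imine, would move the number, since all four compounds share that part.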